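The source may report more compounds than this note shows. Statements on the series, on what has been measured and on what is new or still open speak of the compounds shown alone.

Measured so far:
- compound 1 `COc1ccc(OC)c(C2OC(c3cc(OC)c(OC)c(OC)c3)=NN2C(C)=O)c1`: 37.2%
- compound 2 `COc1cc(C2=NN(C(C)=O)C(c3cc(OC)c(OC)c(OC)c3)O2)cc(OC)c1OC`: -1.8%

Both were run in a functional assay on PC-3 cells (Homo sapiens) for antiproliferative activity, read by MTT assay, tested at 1 uM; a higher number here means a stronger effect of the compound at the concentration tested, a lower number a weaker effect. Compound 1 stands highest of the two numbers; the nearest is compound 2, whose value lies well below it, beyond the scatter. Among the compounds with values here, no step between measured compounds that differ in one place is available, so the series so far gives no direct measure of how a change on the saturated ring carbon moves the read-out.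

Compound 3 `COc1cc(C2=NN(C(C)=O)C(c3ccc(F)c(F)c3)O2)cc(OC)c1OC` has not yet been measured in this assay. It differs from compound 1 as follows: 3,4-difluorophenyl in place of 2,5-dimethoxyphenyl on a saturated ring carbon. Within the data shown here, the only guide is the value of compound 1 37.2%, since two methoxy groups leave and two fluorines enter, with a loss of both acceptors; the direction of such a change is not read from the present data. A moderate downward step is expected, a number 15.2 percentage points lower from compound 1 to compound 3 (beyond the scatter), beyond the scatter but not back to zero. Compound 3 is therefore estimated at 22%, with a range of 2% to 45%.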

Compound 3, a percentage reported as inhibition, at one concentration (the size of the read-out at that concentration, not a potency): 35.5%
Compound 3: middle estimate off by 13.5 percentage points, on the low side, and the stated range covers the measured number.
By their numbers in this assay, from the lowest: compound 2; then compounds 3 and 1 (each within the scatter of the next).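

In this assay, within the data shown here, the change on the saturated ring carbon gives a number 1.7 percentage points lower from compound 1 to compound 3 (within the scatter), the first direct step at this position. At this concentration, 3,4-difluorophenyl and 2,5-dimethoxyphenyl are not told apart at this carbon, so within this pair the read-out does not depend on the hydrogen-bond acceptors that leave with the two methoxy groups. No measured evidence bears on why the two groups read alike.

On these data alone, it remains open whether this position also accepts something other than a substituted phenyl ring, such as an amine, a carboxylic acid or a longer alkyl chain. A single step also cannot show whether the fluorines and the methoxy groups would read alike on other ring positions.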